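A few compounds are considered here, and "the series" means these few. Any claim that something is new, unique, unknown or untested is made for them only; others in the source may bear on it.

In a functional assay on CWR22R cells (Homo sapiens) for antiproliferative activity, read by propidium iodide staining, with a stated time of 96 h (a lower number here means a stronger inhibitor, a higher number a weaker inhibitor), compound 1 `CC(O)(COc1ccc(C#N)cc1C(F)(F)F)C(=O)Nc1cccc(S(F)(F)(F)(F)F)c1` gives 18300 nM and compound 2 `CC(O)(COc1ccc(C#N)c(F)c1)C(=O)Nc1cccc(S(F)(F)(F)(F)F)c1` gives 63400 nM. Compound 3 `CC1(C)C(=O)N(c2ccc(S(F)(F)(F)(F)F)cc2)C(=S)N1c1ccc(C(F)(F)F)cc1`, built on a different core, gives 100000 nM. That number lies within the scatter of compound 2, while compound 1 has a lower number, beyond the scatter from compound 3.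

Compound 4 `CC1(C)C(=O)N(c2ccc(S(F)(F)(F)(F)F)cc2)C(=S)N1c1cccc(C(F)(F)F)c1` has the same atoms as compound 3, joined differently. It carries 3-(trifluoromethyl)phenyl in place of 4-(trifluoromethyl)phenyl on an amide-type nitrogen in a ring. The trifluoromethyl group therefore changes its place while the rest of the molecule stays the same.

Among the compounds with values here, no two measured compounds differ in only one place, so the data offer no direct guide to this swap. The closest reference is compound 3 itself at 100000 nM, so no step beyond the scatter is expected. The estimate is a 1.7-fold lower number from compound 3 to compound 4 (0.22 log units; within the scatter), in the direction of a lower number. For compound 4 the estimated value is 60000 nM, with an expected range from 20000 nM to 100000 nM.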

Compound 4, half-maximal inhibitory concentration: 59600 nM
For compound 4 the middle estimate is 1.0-fold (0.00 log units) above the measured one, and the stated range covers the measured number.
By their numbers in this assay, from the lowest: compound 1; then compounds 4, 2 and 3 (each within the scatter of the next).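

Compound 3 and compound 4 form the only pair shown that differs in one place, so the position of the trifluoromethyl group on the phenyl ring can be read directly. In this assay the swap of 4-(trifluoromethyl)phenyl for 3-(trifluoromethyl)phenyl on the amide-type nitrogen gives no clear separation between the two compounds (a 1.7-fold lower number from compound 3 to compound 4 (0.22 log units; within the scatter)). No measurement shown explains this result.

The compounds shown leave open whether an amine or a carboxylic acid in place of the trifluoromethyl group on this phenyl ring would give a step beyond the scatter. They also leave open whether moving the trifluoromethyl group in the same way would have so small an effect on a different core.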